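A few compounds are considered here, and "the series" means these few. Any claim that something is new, unique, unknown or untested is made for them only; others in the source may bear on it.

In a functional assay on SGC-7901 cells (Homo sapiens) for antiproliferative activity, read by MTT assay, with a stated time of 72 h (a lower number here means a stronger inhibitor, a higher number a weaker inhibitor), compound 1 (`CCOc1ccc(-c2ccc3ncn(-c4cc(OC)c(OC)c(OC)c4)c3c2)cc1`) gives 2970 nM while compound 2 (`COc1cc(-n2cnc3ccc(-c4cccc(Cl)c4)cc32)cc(OC)c1OC`) gives 1490 nM and compound 3 (`COc1cc(-n2cnc3ccc(-c4cccc(C)c4)cc32)cc(OC)c1OC`) gives 1240 nM on the same shared core. Compound 3 stands level with compound 2 (a 1.2-fold lower number from compound 2 to compound 3 (0.08 log units; within the scatter)) and apart from compound 1 (a 2.4-fold lower number from compound 1 to compound 3 (0.38 log units; beyond the scatter)). Compound 4 (`COc1ccc(-c2ccc3ncn(-c4cc(OC)c(OC)c(OC)c4)c3c2)cc1`) has 4-methoxyphenyl in place of 3-methylphenyl on an aromatic carbon. The closest guide is compound 1, whose 4-ethoxyphenyl group gave way to 3-chlorophenyl in one modest step (a 2.0-fold lower number from compound 1 to compound 2 (0.30 log units; within the scatter)) and to 3-methylphenyl in the other noted above. Compound 4 may therefore partly reverse that move, so a small rise in the number is expected (a 1.6-fold higher number from compound 3 to compound 4 (0.21 log units; within the scatter)) in this assay here. Compound 4 is estimated at 2000 nM (range 850 nM to 4500 nM) in this measurement.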

Compound 4, half-maximal inhibitory concentration: 82 nM
Compound 4: middle estimate off by 24-fold (1.39 log units), on the high side, and the stated range ends above it.
By their numbers in this assay, from the lowest: compound 4; then compounds 3, 2 and 1 (each within the scatter of the next, the first and the last beyond it).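

In this assay, the change to 4-methoxyphenyl gives a 15-fold lower number from compound 3 to compound 4 (1.18 log units; beyond the scatter) and an 18-fold lower number from compound 2 to compound 4 (1.26 log units; beyond the scatter) at this aromatic carbon, so compound 4 stands clearly apart from both. The 4-ethoxyphenyl group of compound 1 sits at the same place, yet removing one methyl from its chain gives a 36-fold lower number from compound 1 to compound 4 (1.56 log units; beyond the scatter), which shows that the result turns on the exact length of this chain. Nothing given here explains this gain. Still open, as far as these compounds go, is whether 4-hydroxyphenyl would hold the low number, and whether 3-methoxyphenyl would.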